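Working notes: side-chain step from compound 3 to compound 4

A few compounds are considered here, and "the series" means these few. Any claim that something is new, unique, unknown or untested is made for them only; others in the source may bear on it.

compound 1 `COc1ncc(-c2ccc3ncc(NCc4ccc(C(F)(F)F)cc4)c(OC)c3c2)cc1NS(=O)(=O)c1ccc(F)cc1F` gives 2880 nM
compound 2 `COc1ncc(-c2ccc3ncc(NCC4CCCCC4)c(OC)c3c2)cc1NS(=O)(=O)c1ccc(F)cc1F` gives 9000 nM
compound 3 `CCNc1cnc2ccc(-c3cnc(OC)c(NS(=O)(=O)c4ccc(F)cc4F)c3)cc2c1OC` gives 4820 nM

In a functional assay on PC-3 cells (Homo sapiens) for antiproliferative activity, read by sulforhodamine B assay, with a stated time of 72 h (a higher number here means a weaker inhibitor, a lower number a stronger inhibitor), compound 3 is not separated from either of the other two compounds, with a 1.7-fold higher number from compound 1 to compound 3 (0.22 log units; within the scatter) and a 1.9-fold lower number from compound 2 to compound 3 (0.27 log units; within the scatter) as its two steps. Among the measured compounds shown here, only one measured step exceeds the scatter, namely a 3.1-fold higher number from compound 1 to compound 2 (0.49 log units; beyond the scatter) in this series.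

The next compound is compound 4 `COc1ncc(-c2ccc3ncc(NCC4CCN(S(C)(=O)=O)CC4)c(OC)c3c2)cc1NS(=O)(=O)c1ccc(F)cc1F`, and the change from compound 3 is as follows: 1-(methylsulfonyl)piperidin-4-yl in place of methyl on a saturated chain carbon bound to a nitrogen on an aromatic ring in this one place. In words, this is 1-(methylsulfonyl)piperidin-4-yl in place of methyl on a saturated chain carbon bound to a nitrogen on an aromatic ring.

All three measured steps bear on this change, since each swaps the group at that same carbon, and the largest is modest. The nearest measured case is compound 2, which carries cyclohexyl there and gives 9000 nM in the same test. Its step to compound 3 lies within the scatter, so the group entering here has no clear direction to follow. The step expected in this assay is therefore small (a 1.1-fold higher number from compound 3 to compound 4 (0.06 log units; within the scatter)), with no change beyond the scatter anticipated.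

The estimate for compound 4 is 5500 nM (expected range 2000 nM to 15000 nM).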

Compound 4, half-maximal inhibitory concentration: 2850 nM
The estimate for compound 4 lay 1.9-fold (0.29 log units) above the measured number, within the range that was stated.
By their numbers in this assay, from the lowest: compounds 4, 1, 3 and 2 (each within the scatter of the next, the first and the last beyond it).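

In this assay, the side chain gives its first step beyond the scatter involving a saturated ring that carries a hetero atom: replacing cyclohexyl with 1-(methylsulfonyl)piperidin-4-yl at the saturated chain carbon gives a 3.2-fold lower number from compound 2 to compound 4 (0.50 log units; beyond the scatter). A six-membered non-aromatic ring at this carbon therefore does not by itself fix the value at the level of compound 2, and what the ring carries matters in this pair, although the step is only modest. The other two changes, a 1.7-fold lower number from compound 3 to compound 4 (0.23 log units; within the scatter) and a 1.0-fold lower number from compound 1 to compound 4 (0.00 log units; within the scatter), stay within the scatter, so methyl, 4-(trifluoromethyl)phenyl and the new group are not separated here, and no measurement available accounts for the step from cyclohexyl.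

The compounds shown leave open whether that step belongs to the ring nitrogen or to the methylsulfonyl group, which a piperidine with a free amine or an acetyl group in place of methylsulfonyl could separate. Going by these compounds, it also remains open whether any group at this carbon, such as a carboxylic acid or a longer chain ending in an amine, can move the number clearly below those of compound 1, compound 3 and compound 4.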